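Dialkylamino variation on the anilino ring of compound 1

The source may report more compounds than this note shows. Statements on the series, on what has been measured and on what is new or still open speak of the compounds shown alone.

Measured so far:
Compound 1 `CCC(=O)Nc1cccc(Oc2nc(Nc3ccc(N(C)C)cc3OC)ncc2Cl)c1` gives 80.6% in an assay on isolated protein for inhibition of NUAK family SNF1-like kinase 1 (Homo sapiens), read by ADP-Glo, with a stated time of 60 min, tested at 10 uM, in the presence of a further agent that is not named here; a higher number here means more inhibition at the concentration tested (going by the name of the read-out), a lower number less inhibition.
Compound 2 `CCC(=O)Nc1cccc(Oc2ccnc(Nc3ccc(N4CCN(C)CC4)cc3)n2)c1` gives 85.6% in this assay.
Compound 3 `CCC(=O)Nc1cccc(Oc2nc(Nc3ccc(N(C)C)cc3)ncc2Cl)c1` gives 72.6% in this assay.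

Compound 1 stands second highest of the three numbers in this assay; compound 2 and compound 3 both lie within the scatter of it, so no order among the three is claimed. Compound 4 `CCCN(CCC)c1ccc(Nc2ncc(Cl)c(Oc3cccc(NC(=O)CC)c3)n2)c(OC)c1` differs from compound 1 in one place: dipropylamino in place of dimethylamino on an aromatic carbon. For the measured compounds named here, no measured step changes this dialkylamino group, so none bears directly on it. Going by the values given here, the one measured step, a number 8 percentage points lower from compound 1 to compound 3 (within the scatter), removes the methoxy group and stays within the scatter. With nothing pointing either way, a step in this assay of no more than the scatter is expected, the expected step being a number 5.6 percentage points lower from compound 1 to compound 4 (within the scatter). Compound 4 is therefore estimated at 75%, in a range from 55% to 90%.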

Compound 4, a percentage reported as inhibition, at one concentration (the size of the read-out at that concentration, not a potency): "not active" (no number reported)
The entry for compound 4 holds no number; there is nothing to compare the estimate with.
By their numbers in this assay, from the lowest: compounds 3, 1 and 2 (each within the scatter of the next, the first and the last beyond it).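

For the compounds shown here, compound 4 is recorded as "not active" with no number in this assay, so no step from compound 1 to compound 4 can be read, and no measured evidence bears on this result. The compounds shown leave open how dialkylamino groups between dimethylamino and dipropylamino would read out.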